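Methyl on the Phenyl Ring Across Two Acyl Groups

A few compounds are considered here, and "the series" means these few. Any claim that something is new, unique, unknown or untested is made for them only; others in the source may bear on it.

Compound 1 `COc1ccc2ccc(=O)oc2c1C1=NN(C(C)=O)C(c2ccccc2)C1` gives 52 nM in a functional assay on HepG2 cells (Homo sapiens) for cytotoxicity, read by MTT assay, with a stated time of 72 h; a lower number here means a stronger inhibitor, a higher number a weaker inhibitor. Compound 2 `COc1ccc2ccc(=O)oc2c1C1=NN(C(C)=O)C(c2ccc(C)cc2)C1` carries the change methyl in place of hydrogen on an aromatic carbon and gives 50 nM in this assay, so that a 1.0-fold lower number from compound 1 to compound 2 (0.02 log units; within the scatter). Compound 3 `COc1ccc2ccc(=O)oc2c1C1=NN(C(N)=O)C(c2ccccc2)C1` differs from compound 1 by amino in place of methyl on a carbonyl carbon; in this assay compound 3 gives 90 nM, and a 1.7-fold higher number from compound 1 to compound 3 (0.24 log units; within the scatter). Among the compounds with values here, compound 2 and compound 3 have no step counted between them; their two values lie within the usual scatter of each other.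

Compound 4 `COc1ccc2ccc(=O)oc2c1C1=NN(C(N)=O)C(c2ccc(C)cc2)C1` has not yet been measured. It differs from compound 3 by methyl in place of hydrogen on an aromatic carbon, the same change that separates compound 2 from compound 1, occurring twice among these compounds; the place of the change is described in the same words in both pairs. Because that earlier step read a 1.0-fold lower number from compound 1 to compound 2 (0.02 log units; within the scatter), compound 4 is expected to show a step of a 1.1-fold lower number from compound 3 to compound 4 (0.02 log units; within the scatter). Compound 4 is therefore estimated to give 85 nM in this assay, with a likely range from 45 nM to 170 nM.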

Compound 4, half-maximal inhibitory concentration: 46 nM
Beside the measured number, compound 4's estimate is 1.8-fold (0.27 log units) above it, within the range that was stated.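

Carried from the core of compound 1 to the core of compound 3, methyl in place of hydrogen on an aromatic carbon gives a 2.0-fold lower number from compound 3 to compound 4 (0.29 log units; within the scatter) in this assay, and the two readings of this change do not differ beyond the scatter: the same change on two cores in this assay, a 1.0-fold lower number (0.02 log units; within the scatter) from compound 1 to compound 2 and a 2.0-fold lower number (0.29 log units; within the scatter) from compound 3 to compound 4, 1.9-fold (0.27 log units) apart, within the scatter of two such steps

Amino in place of methyl on a carbonyl carbon, carried onto the 4-methylphenyl compounds, gives a 1.1-fold lower number from compound 2 to compound 4 (0.04 log units; within the scatter), and it too reads alike on both cores within the scatter: the same change on two cores in this assay, a 1.7-fold higher number (0.24 log units; within the scatter) from compound 1 to compound 3 and a 1.1-fold lower number (0.04 log units; within the scatter) from compound 2 to compound 4, 1.9-fold (0.27 log units) apart, within the scatter of two such steps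

The four compounds thus show no sign that either change depends on the core, but every step among them lies within the scatter, so they do not show that either change has any effect of its own, and each comparison rests on a single pair of steps.

The compounds shown leave open whether a chlorine atom, a methoxy group or a longer chain in place of the methyl on the phenyl ring would give a step beyond the scatter. They also leave open how an ethyl group or a substituted amine on the carbonyl carbon would read.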